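The source may hold more compounds than are shown below. What is called first, only, known or untested is meant among the compounds shown, and "the series" means these compounds.

In a functional assay on MGC-803 cells (Homo sapiens) for inhibition, read by MTT assay, with a stated time of 72 h (a lower number here means a stronger inhibitor, a higher number a weaker inhibitor), compound 1 (`O=C(NCc1ccc(NC(=O)c2cccc(F)c2N2CCCC2)cc1)OCc1cccnc1`) gives > 100000 nM, which is a limit of the assay and not a number. Two related compounds have measured values: compound 2 (`O=C(NCc1ccc(NC(=O)c2cc(F)ccc2N2CCCC2)cc1)OCc1cccnc1`) gives 10700 nM, and compound 3 (`COc1ccc(N2CCCC2)c(C(=O)Nc2ccc(CNC(=O)OCc3cccnc3)cc2)c1`) gives 85700 nM. Compound 4 (`Cc1cccc(C(=O)Nc2ccc(CNC(=O)OCc3cccnc3)cc2)c1N1CCCC1`) differs from compound 1 by methyl in place of fluoro on an aromatic carbon, ortho to a pyrrolidin-1-yl group. Within the data shown here, the one measured step that bears on this change is another replacement of fluoro, an 8.0-fold higher number from compound 2 to compound 3 (0.90 log units; beyond the scatter). That modest step lies beyond the scatter, but it brings in methoxy rather than methyl and starts from a measured value, so it guides the expectation only loosely. It gives no support for a large fall in the number in this assay, and compound 4 is expected to remain a weak inhibitor. The expected change is small, toward a lower number if it can be seen at all: an at least 1.4-fold lower number from compound 1 to compound 4 (0.15 log units; that floor lies within the scatter). For compound 4 the estimate is 70000 nM, with an expected range of 25000 nM to 100000 nM.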

Compound 4, half-maximal inhibitory concentration: > 100000 nM
Compound 4 ended at the assay's limit; the forecaster's own chance of this, stated with the estimate: 50%; at least 1.4-fold (0.15 log units) between middle value and limit.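

Compound 1 and compound 4 both end at a limit of this assay and not at a number, so the step between them cannot be read: the limit of > 100000 nM in this assay, at which 2 of the 4 values shown sit.

The compounds shown leave open whether methyl in place of fluoro, ortho to a pyrrolidin-1-yl group, changes the number in this assay at all.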